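This account rests on a few compounds, and the source may have more. Where it says the series, first, only, none or still open, it means among the compounds named here.

Of the compounds shown here, three built on one shared core have been tested in a functional assay on DU-145 cells (Homo sapiens) for inhibition, read by MTT assay, with a stated time of 24 h; on this read-out lower numbers stand for stronger inhibition and higher numbers for weaker inhibition. Compound 1 `CCOC(=O)C1=Cc2ccccc2OC1(OCc1cn(-c2ccc(C)cc2)nn1)C(F)(F)F` gives 30200 nM in this assay. Compound 3 `CCOC(=O)C1=Cc2ccccc2OC1(OCc1cc(-c2cccc(C(F)(F)F)c2)no1)C(F)(F)F` gives 57300 nM, and compound 2 `O=C(O)C1=Cc2ccccc2OC1(OCc1cc(-c2ccc([N+](=O)[O-])cc2)no1)C(F)(F)F` gives 100000 nM. Compound 1 therefore shows the lowest of the three numbers, but its gap to compound 3 falls within the usual scatter of repeated measurements, so those two cannot be told apart; only its gap to compound 2 lies beyond the scatter. None of the three numbers points to strong inhibition.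

Compound 4 `CCOC(=O)C1=Cc2ccccc2OC1(OCc1cn(CC(=O)NC2CCCCC2)nn1)C(F)(F)F` has not yet been measured. It differs from compound 1 in a single place: (cyclohexylcarbamoyl)methyl in place of 4-methylphenyl on an aromatic nitrogen. Going by the values given here, no pair of measured compounds differs by a change of this kind, so there is no measured step to lean on, and the expectation for this assay rests on compound 1 alone. The expected step is a 1.3-fold higher number from compound 1 to compound 4 (0.12 log units; within the scatter), which stays within the scatter and carries no clear direction. Compound 4 is accordingly estimated at 40000 nM in this assay, with a range from 15000 nM to 100000 nM.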

Compound 4, half-maximal inhibitory concentration: 10200 nM
The estimate for compound 4 lay 3.9-fold (0.59 log units) above the measured number; measured number outside the range, below it.
By their numbers in this assay, from the lowest: compound 4; then compounds 1, 3 and 2 (each within the scatter of the next, the first and the last beyond it).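

In this assay, replacing 4-methylphenyl with (cyclohexylcarbamoyl)methyl on the aromatic nitrogen gives a 3.0-fold lower number from compound 1 to compound 4 (0.47 log units; beyond the scatter), a modest change but one that lies beyond the scatter. Going by these compounds alone, this is the first sign that the group at this position can shift the read-out, and it shows that a six-membered aromatic ring is not needed there, since compound 4 carries a non-aromatic ring and an amide instead. Nothing shown explains why the number falls. As far as these compounds go, the change swaps several features at once, so it remains open whether the amide, the cyclohexyl ring or the longer link to the ring matters most. A plain cyclohexyl on the same nitrogen, or a benzyl group, would be the kind of neighbour that could begin to separate these parts.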